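The source may hold more compounds than are shown below. What is called first, only, known or untested is meant among the compounds shown, and "the series" means these compounds.

In a functional assay on K562 cells (Homo sapiens) for cytotoxicity, read by MTT assay, with a stated time of 72 h (a higher number here means a weaker inhibitor, a lower number a stronger inhibitor), the measured compounds read:
compound 1 `C=C1C(=O)[C@@]23C(=O)OC[C@]4(C(=O)CCC(C)(C)[C@H]4C=O)[C@@H]2CC[C@@H]1[C@H]3OC(C)=O` at 1390 nM
compound 2 `C=C1C(=O)[C@@]23C(=O)OC[C@]4(C(=O)CCC(C)(C)[C@H]4C=O)[C@@H]2CC[C@@H]1[C@H]3OC(=O)c1ccccc1` at 1480 nM
compound 3 `C=C1C(=O)[C@@]23C(=O)OC[C@]4(C(=O)CCC(C)(C)[C@H]4C=O)[C@@H]2CC[C@@H]1[C@H]3OC(=O)c1ccc(OC)cc1` at 1650 nM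

Compound 2 stands within the scatter of both other compounds, so the three values do not separate. Phenyl in place of methyl on a carbonyl carbon gave a 1.1-fold higher number from compound 1 to compound 2 (0.03 log units; within the scatter), and 4-methoxyphenyl in its place gave a 1.2-fold higher number from compound 1 to compound 3 (0.07 log units; within the scatter). Methoxy in place of hydrogen on an aromatic carbon gave a 1.1-fold higher number from compound 2 to compound 3 (0.05 log units; within the scatter).

Compound 4 `C=C1C(=O)[C@@]23C(=O)OC[C@]4(C(=O)CCC(C)(C)[C@H]4C=O)[C@@H]2CC[C@@H]1[C@H]3OC(=O)c1ccccc1Cl` has chloro in place of hydrogen on an aromatic carbon, ortho to a large group: chloro in place of hydrogen on an aromatic carbon. The methoxy step is the nearest measured precedent, as a change on the same aromatic ring, but it involves a different group. Among the measured compounds shown here, no chloro compound has been measured, so the precedent is only partial. All three measured steps stayed within the scatter, so the step expected in this assay is a 1.0-fold higher number from compound 2 to compound 4 (0.01 log units; within the scatter), with no direction favoured and nothing expected beyond the scatter. For compound 4 the estimated value is 1500 nM, with an expected range from 900 nM to 2500 nM.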

Compound 4, half-maximal inhibitory concentration: 1220 nM
Estimate against measurement, compound 4: 1.2-fold (0.09 log units) above; the range from low to high includes it.
By their numbers in this assay, from the lowest: compounds 4, 1, 2 and 3 (each within the scatter of the next).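

In this assay chloro in place of hydrogen on an aromatic carbon, ortho to a large group, gave a 1.2-fold lower number from compound 2 to compound 4 (0.08 log units; within the scatter), so this new place on the ring takes a chlorine without a readable shift. 2-Chlorophenyl in place of 4-methoxyphenyl on a carbonyl carbon gave a 1.4-fold lower number from compound 3 to compound 4 (0.13 log units; within the scatter) and 2-chlorophenyl in place of methyl gave a 1.1-fold lower number from compound 1 to compound 4 (0.06 log units; within the scatter), so the four compounds still do not separate, and a substituent at either ring place leaves the number within the scatter. No measurement shown bears on a reason for this flat reading.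

Open, on these data alone, is whether an amine or a carboxylic acid on the aromatic ring, or a longer chain in place of the methyl of compound 1, would move the number beyond the scatter. Also open, as far as these compounds go, is what replacing the ester link itself would do, since all four compounds keep it on the shared core.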